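A few compounds are considered here, and "the series" means these few. Any claim that something is new, unique, unknown or untested is made for them only; others in the source may bear on it.

Measured compounds in an in vivo ADME assay on the whole organism (blood) for pharmacokinetics, with Rattus norvegicus as the target; on this read-out lower numbers stand for slow clearance and higher numbers for fast clearance:
compound 1 `Cc1cc(C(=O)Nc2ccccc2)nn1Cc1cc(Cl)ccc1OCc1ccccc1` – "not determined" (no result reported)
compound 2 `Cc1cc(C(=O)NCc2ccccc2)nn1Cc1cc(Cl)ccc1OCc1ccccc1` – 75 mL/min/kg
compound 3 `Cc1cc(C(=O)NCc2ccccn2)nn1Cc1cc(Cl)ccc1OCc1ccccc1` – 68 mL/min/kg

Compound 3 gives the lower of the two numbers reported, but its nearest neighbour compound 2 sits only a 1.1-fold lower number from compound 2 to compound 3 (0.04 log units; within the scatter) away, so the two values show no separation. Among the measured compounds shown here, the step from compound 2 to compound 3 is the only measured step in this set, and it changes the group on the saturated chain carbon bound to the amide-type nitrogen; it did not move this assay beyond the scatter.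

Compound 4 `Cc1cc(NC(=O)C2CCOCC2)nn1Cc1cc(Cl)ccc1OCc1ccccc1` is not yet measured. It differs from compound 3 by ((oxan-4-yl)carbonyl)amino in place of ((pyridin-2-yl)methyl)carbamoyl on an aromatic carbon. For the measured compounds named here, no measured step touches this kind of change: the one step available alters only the aromatic group hanging from the amide, not the amide itself or its direction. Going by the values given here, with both measured neighbours on fast clearance and no step of any size seen so far, the working expectation for compound 4 is no change beyond the scatter, which would mean a 1.1-fold lower number from compound 3 to compound 4 (0.05 log units; within the scatter) in this assay. Compound 4 is therefore estimated at 60 mL/min/kg, with a range from 30 mL/min/kg to 110 mL/min/kg that is kept wide for want of any step bearing on an amide reversal.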

Compound 4, clearance: 55 mL/min/kg
Beside the measured number, compound 4's estimate is 1.1-fold (0.04 log units) above it; measured number inside the range.
By their numbers in this assay, from the lowest: compounds 4, 3 and 2 (each within the scatter of the next).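

In this assay the aromatic carbon of the shared core accepts ((oxan-4-yl)carbonyl)amino in place of ((pyridin-2-yl)methyl)carbamoyl, with a 1.2-fold lower number from compound 3 to compound 4 (0.09 log units; within the scatter), and in place of benzylcarbamoyl, with a 1.4-fold lower number from compound 2 to compound 4 (0.13 log units; within the scatter). The earlier step exchanged only the aromatic ring at the far end of the chain, whereas these two exchange the whole group: the amide is reversed, so that its nitrogen rather than its carbonyl stands on the aromatic carbon, and a six-membered non-aromatic ring takes the place of the aromatic one. Even so, neither step lies beyond the scatter, so at this position, among the groups shown, neither the direction of the amide nor the kind of ring separates these compounds on this read-out.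

Open, from the compounds shown here alone, is whether a group of another type on this aromatic carbon, such as a carboxylic acid or a piperidine amine, would give a step beyond the scatter, since all three compared groups are amides that end in a six-membered ring. No measurement in hand speaks to what lies behind these values.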